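Swapping Methylamino for Fluoro on an Aromatic Ring

The compounds below may be only part of what the source reports. "The series", "measured", "known", "first", "only" and "open" are said of these compounds alone.

Three related compounds have been examined in an ADME assay on CEMx174 cells (Homo sapiens) for cytotoxicity; on this read-out lower numbers stand for higher toxicity in this test and higher numbers for lower toxicity in this test. Compound 1 `CC1=C(C(=O)NCC2CCCCC2)C(c2cccc(O)c2)NC(=O)N1` has no figure to offer, and its entry reads "not determined" (no result reported). Compound 2 `CC1=C(C(=O)OCC2CCCCC2)C(c2cccc(O)c2)NC(=O)N1C` gives > 10000 nM, which is a limit of the assay and not a number. Compound 3 `CCC1=C(C(=O)OCC2CCCCC2)C(c2ccc(NC)cc2)NC(=O)N1` gives > 10000 nM, which is also a limit of the assay and not a number. This places compound 3 at the limit of > 10000 nM in this assay, at which 2 of the 3 values shown sit.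

Compound 4 `CCC1=C(C(=O)OCC2CCCCC2)C(c2ccc(F)cc2)NC(=O)N1` has not yet been measured. It differs from compound 3 in one place: fluoro in place of methylamino on an aromatic carbon. Seen as a whole group, 4-(methylamino)phenyl becomes 4-fluorophenyl.

For the measured compounds named here, no measured pair shows what a single change does in this assay, so the expectation rests on the limit shared by the two compounds with a reported result. The expected step that the limit leaves unreadable from compound 3 to compound 4 is nothing beyond the scatter, with no clear direction. Compound 4 is estimated at 15000 nM, with an expected range of 6000 nM to 40000 nM.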

Compound 4, half-maximal cytotoxic concentration: > 10000 nM
Compound 4 ended at the assay's limit; the forecaster's own chance of this, stated with the estimate: 80%; the middle value does not contradict the limit.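

For the compounds shown here, no step from compound 3 to compound 4 can be read in this assay, because both results are limits of the assay and not numbers: the limit of > 10000 nM in this assay, at which 3 of the 4 values shown sit.

The compounds shown leave open where the true values of compound 3 and compound 4 lie, and so whether fluoro in place of methylamino changes anything in this test.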